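Acyl chain growth on the amide of the shared core

The source may hold more compounds than are shown below. What is called first, only, known or untested is meant among the compounds shown, and "the series" means these compounds.

Measured compounds in a functional assay on HL-60 cells (Homo sapiens) for antiproliferative activity, read by MTT assay, with a stated time of 72 h; a lower number here means a stronger inhibitor, a higher number a weaker inhibitor:
compound 1 `CC(=O)N(C)c1ccc2[nH]c(-c3n[nH]c4ccccc34)cc2n1` gives 5110 nM
compound 2 `CCC(=O)N(C)c1ccc2[nH]c(-c3n[nH]c4ccccc34)cc2n1` gives 6130 nM

Among the measured compounds shown here, compound 2 stands as the highest of the two numbers measured so far in this assay; its nearest neighbour is compound 1, and the step of a 1.2-fold higher number from compound 1 to compound 2 (0.08 log units; within the scatter) lies within the scatter, so the two are not separable on this evidence.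

The next compound, compound 3 `CN(C(=O)C(C)(C)C)c1ccc2[nH]c(-c3n[nH]c4ccccc34)cc2n1`, is not yet measured. It differs from compound 2 as follows: tert-butyl in place of ethyl on a carbonyl carbon. For the measured compounds named here, the only measured step that bears on this change is the one from compound 1 to compound 2, which also grows the acyl chain at the same carbonyl carbon, and that step was small, a 1.2-fold higher number from compound 1 to compound 2 (0.08 log units; within the scatter). The change to compound 3 is a larger growth of the same kind. Going by the values given here, no measured pair shows a chain of this size, so the expectation rests on extending the one small step seen.

On that basis the expected step for compound 3 is a 1.4-fold higher number from compound 2 to compound 3 (0.14 log units; within the scatter), a modest rise in number that may not clear the scatter. The estimate for compound 3 in this assay is 8500 nM, with a range from 3500 nM to 22000 nM.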

Compound 3, half-maximal inhibitory concentration: 4990 nM
Estimate against measurement, compound 3: 1.7-fold (0.23 log units) above; the measured number falls inside the stated range.
By their numbers in this assay, from the lowest: compounds 3, 1 and 2 (each within the scatter of the next).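

In this assay, tert-butyl on the carbonyl carbon gives a 1.2-fold lower number from compound 2 to compound 3 (0.09 log units; within the scatter), and set against methyl at the same carbon it gives a 1.0-fold lower number from compound 1 to compound 3 (0.01 log units; within the scatter). Together with the earlier step, this means that methyl, ethyl and tert-butyl on this carbonyl carbon cannot be told apart in this assay, and the tolerance seen for one small growth of the chain now extends to a group of 4 heavy atoms, with no trend in the numbers across the three compounds. Nothing measured here bears on why the numbers stay level across these groups.

Still open, on these data alone, is whether any group on this carbonyl carbon other than a plain carbon chain, such as an amine, a carboxylic acid or a phenyl ring, would move the number beyond the scatter. All three compounds also keep the methyl on the amide nitrogen and the shared core unchanged, so the response to the amide hydrogen or a longer chain at that nitrogen remains an open question for the series.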